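Ethyl for methyl on the oxadiazole of the benzamide

A few compounds are considered here, and "the series" means these few. Any claim that something is new, unique, unknown or untested is made for them only; others in the source may bear on it.

Measured compounds, with their values in an assay on brain for displacement of a labelled ligand from D(3) dopamine receptor (Rattus norvegicus); on this read-out lower numbers stand for stronger inhibition and higher numbers for weaker inhibition:
compound 1, `CCCN(CC[C@H]1CC[C@H](NC(=O)c2ccc(-n3ccnc3)cc2)CC1)[C@H]1CCc2nc(N)sc2C1`: 1.9 nM
compound 2, `CCCN(CC[C@H]1CC[C@H](NC(=O)c2ccc(-c3noc(C)n3)cc2)CC1)[C@H]1CCc2nc(N)sc2C1`: 1.3 nM

Compound 2 holds the lowest of the two numbers, with compound 1 nearest; the difference, a 1.5-fold lower number from compound 1 to compound 2 (0.16 log units; within the scatter), lies within the scatter, so the two are not separated by this assay. Compound 3, `CCCN(CC[C@H]1CC[C@H](NC(=O)c2ccc(-c3noc(CC)n3)cc2)CC1)[C@H]1CCc2nc(N)sc2C1`, is the next member. It differs from compound 2 by methyl in place of hydrogen on a saturated chain carbon bound to an aromatic carbon. Among the measured compounds shown here, the only measured step, a 1.5-fold lower number from compound 1 to compound 2 (0.16 log units; within the scatter), concerns an exchange of the whole ring on the aromatic carbon and not a chain on such a ring, so it does not bear directly on the change at hand; it shows only that a change at this end of the molecule left this assay essentially unchanged. For the measured compounds named here, no measured step addresses chain extension on the oxadiazole. Compound 3 is therefore expected to stay close to compound 2, with an estimated step of no change at the digits printed from compound 2 to compound 3 (within the scatter), which is no change beyond the scatter. For compound 3 the estimate is 1.3 nM, within a range from 0.5 nM to 3.5 nM.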

Compound 3, inhibition constant: 2.1 nM
The estimate for compound 3 lay 1.6-fold (0.21 log units) below the measured number; measured number inside the range.
By their numbers in this assay, from the lowest: compounds 2, 1 and 3 (each within the scatter of the next).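

In this assay the change from methyl to ethyl gives a 1.6-fold higher number from compound 2 to compound 3 (0.21 log units; within the scatter) and so shows that one added carbon on the saturated chain carbon bound to an aromatic carbon is not separated by this assay. Among the compounds shown here, the earlier step exchanged the whole ring, whereas this is the first reading on the chain itself. With ethyl on the ring, the comparison with 1H-imidazol-1-yl gives a 1.1-fold higher number from compound 1 to compound 3 (0.04 log units; within the scatter) and the three compounds remain unresolved, while no outside evidence bears on this result.

Open, from the compounds shown here alone, is whether a longer chain such as propyl, or a branched group such as isopropyl, stays within the scatter of compound 2 at this place. Also open, going by these compounds, is whether an amine or a carboxylic acid at the end of such a chain would leave the number equally unchanged.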